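This account rests on a few compounds, and the source may have more. Where it says the series, first, only, none or still open, it means among the compounds named here.

In a functional assay on KB cells (Homo sapiens) for cytotoxicity (a higher number here means a weaker inhibitor, a lower number a stronger inhibitor), compound 3 (`COc1ccc(S(=O)(=O)N2CCc3cccc(NC(=O)c4ccccc4)c32)cc1`) gives 297 nM, within the scatter of compound 1 (`COc1ccc(S(=O)(=O)N2CCc3cccc(NC(=O)C(C)(C)C)c32)cc1`) at 359 nM. Compound 2 (`COc1ccc(S(=O)(=O)N2CCc3cc(Br)cc(NC(=O)c4ccco4)c32)cc1`) gives 89 nM, a number lower than that of compound 3 by more than the scatter. Compound 4 (`COc1ccc(S(=O)(=O)N2CCc3cccc(NC(=O)c4ccco4)c32)cc1`) has furan-2-yl in place of phenyl on a carbonyl carbon. Among the measured compounds shown here, the only measured exchange at this place, a 1.2-fold lower number from compound 1 to compound 3 (0.08 log units; within the scatter), stayed within the scatter. Furan-2-yl also stands in compound 2, which additionally carries bromine on the shared core, so the 89 nM of compound 2 pulls the expectation only weakly lower. In this assay, the expected change is small and within the scatter: a 1.5-fold lower number from compound 3 to compound 4 (0.17 log units; within the scatter). For compound 4 the estimated value is 200 nM, with an expected range of 80 nM to 450 nM.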

Compound 4, half-maximal inhibitory concentration: 9.6 nM
Beside the measured number, compound 4's estimate is 21-fold (1.32 log units) above it, outside the stated range (below it).
By their numbers in this assay, from the lowest: compound 4; then compound 2; then compounds 3 and 1 (each within the scatter of the next).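

On the carbonyl carbon, the group matters far more in this assay than the first exchange suggested: furan-2-yl in place of phenyl gives (a 31-fold lower number from compound 3 to compound 4 (1.49 log units; beyond the scatter)) and furan-2-yl in place of tert-butyl gives (a 37-fold lower number from compound 1 to compound 4 (1.57 log units; beyond the scatter)), while phenyl in place of tert-butyl stayed within the scatter (a 1.2-fold lower number from compound 1 to compound 3 (0.08 log units; within the scatter)). With furan-2-yl held fixed, bromine on the shared core also counts, as hydrogen in its place gives (a 9.3-fold lower number from compound 2 to compound 4 (0.97 log units; beyond the scatter)). Nothing at hand accounts for these steps.

As far as these compounds go, whether the furan ring oxygen or the five-membered ring itself carries the step remains open. Thiophen-2-yl on the same carbonyl carbon would separate the two.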